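Sulfur side chain: from compound 1 to compound 3

The compounds below may be only part of what the source reports. "The series", "measured", "known", "first", "only" and "open" are said of these compounds alone.

Compound 1 (`COc1ccc(-n2c(SC)nnc2-c2cc(OC)c(OC)c(OC)c2)cc1`) gives > 60000 nM in a functional assay on PC-3 cells (Homo sapiens) for inhibition, read by MTT assay, with a stated time of 48 h (on this read-out lower numbers stand for stronger inhibition and higher numbers for weaker inhibition), which is a limit of the assay and not a number. Compound 2 (`COc1ccc(-n2c(SCc3ccc(C)cc3)nnc2-c2cc(OC)c(OC)c(OC)c2)cc1`), with 4-methylphenyl in place of hydrogen on the same carbon, gives 56500 nM. Compound 3 (`COc1ccc(-n2c(SCC(=O)c3ccc(F)cc3)nnc2-c2cc(OC)c(OC)c(OC)c2)cc1`) carries (4-fluorophenyl)carbonyl in place of hydrogen on a saturated chain carbon bound to a sulfur. Among the compounds with values here, the only measured step bearing on this change is an at least 1.0-fold lower number from compound 1 to compound 2 (0.02 log units; that floor lies within the scatter), so only a modest shift is expected. The expected step in this assay is an at least 2.0-fold lower number from compound 1 to compound 3 (0.30 log units; that floor lies within the scatter), towards lower numbers. For compound 3 the estimate is 30000 nM, with an expected range of 10000 nM to 60000 nM.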

Compound 3, half-maximal inhibitory concentration: 58300 nM
The estimate for compound 3 lay 1.9-fold (0.29 log units) below the measured number; the range from low to high includes it.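

In this assay the new side chain gives an at least 1.0-fold lower number from compound 1 to compound 3 (0.01 log units; that floor lies within the scatter) and that floor says little, because compound 1 stands at a limit and not at a number: the limit of > 60000 nM in this assay, at which 1 of the 3 values shown sits.
(4-Fluorophenyl)carbonyl in place of 4-methylphenyl on the same carbon gives a 1.0-fold higher number from compound 2 to compound 3 (0.01 log units; within the scatter) and so does not separate these two side chains. At this place, the carbonyl-bearing group and the 4-methylphenyl group therefore read alike.

Open, from the compounds shown here alone, is whether any group here reaches clearly lower numbers. An amine or a carboxylic acid on this carbon, or a longer chain, would test that.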